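Series notes: HeLa cytotoxicity, compound 2 to compound 4

The source may report more compounds than this note shows. Statements on the series, on what has been measured and on what is new or still open speak of the compounds shown alone.

Measured compounds and values in a functional assay on HeLa cells (Homo sapiens) for cytotoxicity, read by MTT assay, with a stated time of 24 h; a higher number here means a weaker inhibitor, a lower number a stronger inhibitor:
- Compound 1 `C=CC1=C(C(=O)NCc2ccccc2)C(c2ccc(OC)c(OC)c2)OC1`: > 100000 nM, a limit of the assay.
- Compound 2 `C=CC1=C(C(=O)NCc2ccc(C)cc2)C(c2ccc(F)cc2)OC1`: > 100000 nM, a limit of the assay.
- Compound 3 `C=CC1=C(C(=O)NCCC)C(c2ccc(Cl)c(Cl)c2)OC1`: > 100000 nM, a limit of the assay.

Every value shown in this assay is a limit and not a number, as summarised by the limit of > 100000 nM in this assay, at which 3 of the 3 values shown sit. Compound 2 therefore cannot be placed above or below compound 1 or compound 3 on these numbers; all that is known is that its value sits at the same limit as the other two.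

Compound 4 `C=CC1=C(C(=O)NCC(C)C)C(c2ccc(F)cc2)OC1` has not yet been measured. It differs from compound 2 by isopropyl in place of 4-methylphenyl on a saturated chain carbon bound to an amide-type nitrogen. Going by the values given here, no pair of measured compounds differing in a single place is available, so no measured step can guide the size of this change. The expectation for the step from compound 2 to compound 4 is a step that the limit leaves unreadable from compound 2 to compound 4, that is, nothing beyond the scatter, because the value of compound 2 is itself a limit (> 100000 nM). Compound 4 is estimated at 150000 nM, with a range from 50000 nM to 500000 nM, and most likely the assay will again report only a limit.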

Compound 4, half-maximal inhibitory concentration: > 100000 nM
Compound 4: no number, only a limit; the forecaster's own chance of this, stated with the estimate: 85%; the middle value does not contradict the limit.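

In this assay compound 2 and compound 4 both return only a limit, and no new step can be read between them: the limit of > 100000 nM in this assay, at which 4 of the 4 values shown sit.

The compounds shown leave open whether any of them has a numerical value in this assay, and whether isopropyl in place of 4-methylphenyl changes anything there.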